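The source may report more compounds than this note shows. Statements on the series, on what has been measured and on what is new or still open speak of the compounds shown alone.

Measured so far in a functional assay on MGC-803 cells (Homo sapiens) for inhibition, read by MTT assay, with a stated time of 48 h; a higher number here means a weaker inhibitor, a lower number a stronger inhibitor:
- Compound 1 `COc1ccc(Nc2nnc(Cl)c(Nc3cc(OC)c(OC)c(OC)c3)n2)cc1`: 19000 nM
- Compound 2 `COc1cc(Nc2nnc(Cl)c(Nc3cc(OC)c(OC)c(OC)c3)n2)cc(OC)c1OC`: 24300 nM
- Compound 3 `CCOC(=O)c1ccc(Nc2nnc(Cl)c(Nc3cc(OC)c(OC)c(OC)c3)n2)cc1`: 53600 nM

Compound 3, at 53600 nM, has the highest number of the three and is the weakest inhibitor in this set, with both others lower by more than the scatter. The next compound, compound 4 `COc1cc(Nc2nc(Nc3ccc(C)cc3)nnc2Cl)cc(OC)c1OC`, keeps the rest of compound 3 and changes one group: methyl in place of ethoxycarbonyl on an aromatic carbon, para to a large group.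

For the measured compounds named here, only one measured step bears on this change: a 2.8-fold higher number from compound 1 to compound 3 (0.45 log units; beyond the scatter), a modest step in which ethoxycarbonyl came in place of methoxy on an aromatic carbon. Going by the values given here, no measured compound carries methyl, so the expectation rests on that single step, read in reverse, and is for a modest move towards a lower number in this assay. The expected change is a 2.7-fold lower number from compound 3 to compound 4 (0.43 log units; beyond the scatter). Compound 4 is estimated at 20000 nM, with an expected range from 9000 nM to 42000 nM.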

Compound 4, half-maximal inhibitory concentration: 19800 nM
Compound 4: the middle estimate sits 1.0-fold (0.00 log units) above what was measured, and the stated range covers the measured number.
By their numbers in this assay, from the lowest: compounds 1, 4 and 2 (each within the scatter of the next); then compound 3.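

In this assay, methyl in place of ethoxycarbonyl gives a 2.7-fold lower number from compound 3 to compound 4 (0.43 log units; beyond the scatter), so the higher number seen with ethoxycarbonyl at this position is not tied to the comparison with methoxy alone. Methyl and methoxy are not told apart here, with a 1.0-fold higher number from compound 1 to compound 4 (0.02 log units; within the scatter), which leaves ethoxycarbonyl as the one group of the three at this position whose compound stands apart from the other two. Nothing measured in these compounds explains this difference.

The compounds shown leave open whether an amine, a carboxylic acid or a longer alkyl chain at this position would group with methyl and methoxy or with ethoxycarbonyl. They also leave open whether a hydrogen or a fluorine there would give a number lower than those of compound 1 and compound 4.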